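Smaller Amino Group on a Corticotropin-Releasing Factor Receptor Core

The source may hold more compounds than are shown below. What is called first, only, known or untested is meant among the compounds shown, and "the series" means these compounds.

Compound 1 `CCCN(CC1CC1)c1nc(C)nc2c(-c3ccc(OC)cc3C)c(C)nn12`: 1.96 nM
Compound 2 `CCCCN(CC)c1nc(C)nc2c(-c3c(C)cc(OC)cc3OC)c(C)nn12`: 1.72 nM
Compound 3 `C=CCN(CC=C)c1nc(C)nc2c(-c3c(C)cc(OC)cc3OC)c(C)nn12`: 1 nM

Three compounds sharing one core were tested in an assay on cell membranes for displacement of a labelled ligand from corticotropin-releasing factor receptor 1 (Rattus norvegicus); on this read-out lower numbers stand for stronger inhibition and higher numbers for weaker inhibition. Compound 1 gives 1.96 nM, compound 2 gives 1.72 nM and compound 3 gives 1 nM. Compound 3 shows the lowest of the three numbers, yet both others lie within the scatter of it, so no ranking among them can be claimed. For the measured compounds named here, the only single-place step among the measured compounds is a 1.7-fold lower number from compound 2 to compound 3 (0.24 log units; within the scatter), an exchange of one amino group for another on the same aromatic carbon, which stayed within the scatter.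

Compound 4 `CCCN(C)c1nc(C)nc2c(-c3c(C)cc(OC)cc3OC)c(C)nn12` differs from compound 3 in one place: methyl(propyl)amino in place of diallylamino on an aromatic carbon. The step of a 1.7-fold lower number from compound 2 to compound 3 (0.24 log units; within the scatter) bears on this change. That step also swapped the amino group at that carbon and moved little. Going by the values given here, no measured compound carries a group as small as methyl(propyl)amino, so the data cannot show how far trimming goes before the number rises. The step to compound 4 is therefore expected to be a 2.5-fold higher number from compound 3 to compound 4 (0.40 log units; beyond the scatter), a modest rise. Compound 4 is expected to give 2.5 nM, with a range from 0.8 nM to 8 nM.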

Compound 4, half-maximal inhibitory concentration: 6.48 nM
The estimate for compound 4 lay 2.6-fold (0.41 log units) below the measured number, and the stated range covers the measured number.
By their numbers in this assay, from the lowest: compounds 3, 2 and 1 (each within the scatter of the next); then compound 4.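

In this assay, this position on the shared core proves sensitive to the amino group it carries. The earlier exchange there stayed within the scatter, but methyl(propyl)amino, with 5 heavy atoms against 7 for diallylamino, gives a 6.5-fold higher number from compound 3 to compound 4 (0.81 log units; beyond the scatter) and, set against butyl(ethyl)amino, a 3.8-fold higher number from compound 2 to compound 4 (0.58 log units; beyond the scatter), so compound 4 stands apart from both. Nothing measured here explains this rise.

The compounds shown leave open whether the rise follows the loss of heavy atoms or the loss of the two double bonds, which a saturated dipropylamino group on the same carbon would help to separate. They also leave open whether a cyclic amine such as pyrrolidine or an ether-bearing chain such as bis(2-methoxyethyl)amino would stay close to compound 3 or rise as compound 4 does.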